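This account rests on a few compounds, and the source may have more. Where it says the series, first, only, none or still open, it means among the compounds named here.

Of the compounds shown here, three built on one shared core have been measured. In a functional assay on HCT-116 cells (Homo sapiens) for antiproliferative activity, read by MTT assay, with a stated time of 48 h (on this read-out higher numbers stand for weaker inhibition and lower numbers for stronger inhibition), compound 1 `O=C(Nc1cccc(/C=C/C(=O)c2nc3ccccc3[nH]2)c1)c1cccc(Cl)c1` gives 1120 nM, compound 2 `COc1cccc(C(=O)Nc2cccc(/C=C/C(=O)c3nc4ccccc4[nH]3)c2)c1` gives 3680 nM, and compound 3 `O=C(/C=C/c1cccc(NS(=O)(=O)c2cccc(Cl)c2)c1)c1nc2ccccc2[nH]1` gives 737 nM. Compound 3 thus holds the lowest of the three numbers; it sits within the scatter of compound 1, as a 1.5-fold lower number from compound 1 to compound 3 (0.18 log units; within the scatter) shows, and clearly apart from compound 2, as a 5.0-fold lower number from compound 2 to compound 3 (0.70 log units; beyond the scatter) shows. Compound 4 `Cc1cccc(S(=O)(=O)Nc2cccc(/C=C/C(=O)c3nc4ccccc4[nH]3)c2)c1` differs from compound 3 by methyl in place of chloro on an aromatic carbon, the (3-chlorophenyl)sulfonyl group becoming (3-methylphenyl)sulfonyl. Within the data shown here, the only measured step that touches that ring is a 3.3-fold higher number from compound 1 to compound 2 (0.52 log units; beyond the scatter), where methoxy rather than methyl replaces chloro, and on an amide rather than a sulfonamide; the other two steps alter the linker instead and say nothing about the ring substituent. On that single and imperfect precedent a small move to a higher number in this assay is expected, though it may well stay within the scatter. Compound 4 is therefore estimated at 1200 nM, with a range from 450 nM to 3200 nM, which would mean an expected step of a 1.6-fold higher number from compound 3 to compound 4 (0.21 log units; within the scatter).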

Compound 4, half-maximal inhibitory concentration: 597 nM
Compound 4: middle estimate off by 2.0-fold (0.30 log units), on the high side, and the stated range covers the measured number.
By their numbers in this assay, from the lowest: compounds 4, 3 and 1 (each within the scatter of the next); then compound 2.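

In this assay, chloro and methyl on this aromatic carbon of the sulfonamide cannot be told apart, as a 1.2-fold lower number from compound 3 to compound 4 (0.09 log units; within the scatter) shows, so this change moves the number no further than the scatter, unlike the methoxy-for-chloro step on the amide, a 3.3-fold higher number from compound 1 to compound 2 (0.52 log units; beyond the scatter). The 3-methylphenyl sulfonamide also stands clearly apart from the methoxy amide, at a 6.2-fold lower number from compound 2 to compound 4 (0.79 log units; beyond the scatter), yet remains within the scatter of the chloro amide, at a 1.9-fold lower number from compound 1 to compound 4 (0.27 log units; within the scatter). Nothing shown accounts for these results.

The compounds shown leave open whether methoxy on the sulfonamide would give a step like the one seen on the amide. They also leave open how this position responds to a group unlike chloro and methyl, such as an amine or a carboxylic acid.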